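This account rests on a few compounds, and the source may have more. Where it says the series, first, only, none or still open, it means among the compounds named here.

Going by the values given here, compound 3 `COc1ccc2[nH]c(C(=O)N3CC(=O)N(Cc4ccccc4)[C@@H](CN4CC5(CCC5)C4)C3)cc2c1` gives the only plain number in a physicochemical assay for solubility, read by spectrophotometry, in phosphate buffer, with a stated time of 2 h, at pH 7.4 (on this read-out lower numbers stand for lower solubility and higher numbers for higher solubility), namely 60700 nM. Compound 1 `COc1ccc2[nH]c(C(=O)N3CC(=O)N(Cc4ccccc4)[C@@H](CN4CCC(OC)CC4)C3)cc2c1` sits at a limit of this assay, > 25000 nM, which is not a number. Compound 2 `COc1ccc2[nH]c(C(=O)N3CC(=O)N(Cc4ccccc4)[C@@H](CN4C(=O)c5ccccc5C4=O)C3)cc2c1` likewise sits at a limit of this assay, > 100000 nM. Compound 4 `COc1ccc2[nH]c(C(=O)N3CC(=O)N(Cc4ccccc4)[C@@H](CN4CCC5(CCCC5)CC4)C3)cc2c1` differs from compound 3 by a group of 10 heavy atoms (9 carbon, 1 nitrogen; one five-membered non-aromatic ring of carbon only, one six-membered non-aromatic ring with 1 hetero atom) in place of a group of 7 heavy atoms (6 carbon, 1 nitrogen; one four-membered non-aromatic ring of carbon only, one four-membered non-aromatic ring with 1 hetero atom), on a saturated chain carbon bound to a saturated ring carbon. Among the compounds with values here, two measured steps touch the same place: an at least 1.6-fold lower number from compound 2 to compound 3 (0.21 log units; that floor lies within the scatter), and a step that the limit leaves unreadable from compound 1 to compound 3. Neither fixes a size, so no step beyond the scatter can be read from them for this change. The step of a 2.0-fold lower number from compound 3 to compound 4 (0.31 log units; beyond the scatter) is therefore an estimate of a modest fall in this assay, held within the scatter. Compound 4 is expected to show 30000 nM in this assay, within a range from 10000 nM to 90000 nM.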

Compound 4, solubility: 5000 nM
For compound 4 the middle estimate is 6.0-fold (0.78 log units) above the measured one; the measured number lies below the stated range.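

Going by these compounds alone, putting the group of 10 heavy atoms in place of the group of 7 heavy atoms, on this saturated chain carbon, gives the first step of readable size in this assay, and it is large: a 12-fold lower number from compound 3 to compound 4 (1.08 log units; beyond the scatter). The other two changes here also lie beyond the scatter: an at least 20-fold lower number from compound 2 to compound 4 (1.30 log units; beyond the scatter) and an at least 5.0-fold lower number from compound 1 to compound 4 (0.69 log units; beyond the scatter). Both of these start from a limit of the assay, so they give only minimum sizes.

From the compounds shown here alone, the groups differ in both size and ring type, so which of these matters stays open. Going by these compounds, how an open-chain diethylamino group or a piperazine would read here also remains open.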